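Chalcone-pyrazole series: aminophenyl to dichlorophenyl exchange

The source may report more compounds than this note shows. Statements on the series, on what has been measured and on what is new or still open speak of the compounds shown alone.

Two compounds of the series have a number in a functional assay on T47D cells (Homo sapiens) for cytotoxicity, read by sulforhodamine B assay, with a stated time of 48 h, tested at 0.01 uM; on this read-out lower numbers stand for a stronger effect and higher numbers for a weaker effect at the one concentration tested. Compound 1 `COc1ccc(-c2cc(/C=C/C(=O)c3ccc(N)cc3)[nH]n2)cc1` gives 98% in this assay. Compound 2 `COc1cc(-c2cc(/C=C/C(=O)c3ccc(N)cc3)[nH]n2)cc(OC)c1OC` gives 83% in this assay, the lower of the two numbers; its nearest neighbour is compound 1, and the gap between them lies beyond the scatter. For the measured compounds named here, no pair among the measured compounds differs in a single place, so no measured step is available for the next change.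

Compound 3 `COc1cc(-c2cc(/C=C/C(=O)c3ccc(Cl)c(Cl)c3)[nH]n2)cc(OC)c1OC` has not yet been measured in this assay. It differs from compound 2 in one place: 3,4-dichlorophenyl in place of 4-aminophenyl on a carbonyl carbon. Nothing in the measured compounds speaks to this exchange, so no step beyond the scatter is expected in either direction, and a small drift toward a higher number is allowed for. For compound 3 the estimated step is a number 7 percentage points higher from compound 2 to compound 3 (within the scatter). Compound 3 is expected to give about 90% in this assay, between 72% and 104%.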

Compound 3, a percentage reported as activity, at one concentration (the size of the read-out at that concentration, not a potency): 90%
Compound 3: middle estimate and measured number agree at the digits printed; measured number inside the range.
By their numbers in this assay, from the lowest: compounds 2, 3 and 1 (each within the scatter of the next, the first and the last beyond it).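

In this assay, for the compounds shown here, the exchange of 4-aminophenyl for 3,4-dichlorophenyl on the carbonyl carbon gives a number 7 percentage points higher from compound 2 to compound 3 (within the scatter) and provides the first measured single-place step. At this position, the read-out therefore stays within the scatter when the amino group is lost and two chlorine atoms enter, so at the one concentration tested it does not depend on keeping 4-aminophenyl. No supporting measurement bears on why the step has this size.

Still open, on these data alone, is how a more different group at this place, such as a carboxylic acid on the phenyl ring or a morpholine ring in place of it, would act in this read-out. Also open, as far as these compounds go, is whether the same exchange on the core of compound 1 would give a step of similar size, and whether this step would hold at other concentrations.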